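This account rests on a few compounds, and the source may have more. Where it says the series, first, only, none or still open, it means among the compounds named here.

Going by the values given here, in a functional assay on MGC-803 cells (Homo sapiens) for inhibition, read by MTT assay, with a stated time of 48 h (a higher number here means a weaker inhibitor, a lower number a stronger inhibitor), compound 1 `COCC(=O)N(Cc1ccc(OC)c(O)c1)c1cc(OC)c(OC)c(OC)c1` gives 79 nM, the only number so far. Compound 2 `COc1cc(NCc2ccc(C)cc2)cc(OC)c1OC` is reported in this assay only as a limit, > 80000 nM. Beyond that stands the limit of > 80000 nM in this assay, at which 1 of the 2 values shown sits, and nothing else. Compound 3 `COc1ccc(CN(C(=O)C2CC2)c2cc(OC)c(OC)c(OC)c2)cc1O` differs from compound 1 in one place, (cyclopropyl in place of methoxymethyl on a carbonyl carbon), the acyl group going from (methoxymethyl)carbonyl to cyclopropylcarbonyl. Among the compounds with values here, no measured pair differing in one place is available, so no step size is known. The expected step is a 1.3-fold lower number from compound 1 to compound 3 (0.12 log units; within the scatter), hardly beyond the scatter in either direction. Compound 3 is estimated at 60 nM, within 20 nM to 200 nM.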

Compound 3, half-maximal inhibitory concentration: 59 nM
Estimate against measurement, compound 3: 1.0-fold (0.01 log units) above; measured number inside the range.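

In this assay, going by these compounds alone, putting cyclopropyl in place of methoxymethyl on a carbonyl carbon gives a 1.3-fold lower number from compound 1 to compound 3 (0.13 log units; within the scatter) and is the first step that can be read at this place. The oxygen of methoxymethyl can thus give way to a three-membered ring of carbon only with no change beyond the scatter. Nothing shown offers an explanation for this result. Going by these compounds, whether an amine, a carboxylic acid or a longer chain on the same carbonyl carbon would also stay within the scatter of these two compounds remains open.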